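Hydroxy Addition on the Aromatic Ring of Compound 2

The source may hold more compounds than are shown below. What is called first, only, known or untested is meant among the compounds shown, and "the series" means these compounds.

Working notes on a small set of tertiary alcohols tested in a functional assay on HepG2 cells (Homo sapiens) for inhibition, read by fluorescence, with a stated time of 60 min; on this read-out lower numbers stand for stronger inhibition and higher numbers for weaker inhibition. Compound 1, `CC(C)=CCC[C@](C)(O)c1ccc(C)cc1`, is the open-chain member. In this assay compound 1 gives > 100000 nM, which is a limit of the assay and not a number. Compound 2, `Cc1ccc([C@]2(C)CC[C@@H](C(C)(C)O)O2)cc1`, carries the cyclic ether in place of the open chain. In this assay compound 2 gives > 100000 nM, again a limit of the assay rather than a measured number. Where compound 2 stands is thus known only as a bound, since the evidence so far is the limit of > 100000 nM in this assay, at which 2 of the 2 values shown sit, and no step between measured compounds can be sized. Compound 3, `Cc1ccc([C@]2(C)CC[C@@H](C(C)(C)O)O2)cc1O`, is not yet measured. It differs from compound 2 by hydroxy in place of hydrogen on an aromatic carbon. Going by the values given here, with no measured step to lean on, the expected step from compound 2 to compound 3 is a number no higher from compound 2 to compound 3 (the limit leaves the size open), that is, none beyond the scatter, and the read-out is expected most likely to come back as a limit once more. The estimate for compound 3 in this assay is 100000 nM, with a range from 30000 nM to 300000 nM.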

Compound 3, half-maximal inhibitory concentration: 31000 nM
Beside the measured number, compound 3's estimate is 3.2-fold (0.51 log units) above it; low and high end bracket the measured number.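

Hydroxy in place of hydrogen on an aromatic carbon, ortho to a methyl group and meta to a large group, gives an at least 3.2-fold lower number from compound 2 to compound 3 (0.50 log units; beyond the scatter) in this assay, and it is the only change shown that brings a read-out off the limit. Going by these compounds alone, compound 3 alone among the three compounds gives a measured number, 31000 nM, so this aromatic carbon is a place where a single added hydroxy registers on the read-out, which neither of the earlier compounds could show. The step remains a floor rather than a measured gap, and its true size stays unknown: the limit of > 100000 nM in this assay, at which 2 of the 3 values shown sit.

Whether the change depends on the hydroxy group itself remains open, since the compounds shown do not tell how a methoxy group, an amine or a fluorine on the same aromatic carbon would read in this assay. Also open, as far as these compounds go, is whether hydroxy at this place would give a measured number on the open-chain core of compound 1, or whether the cyclic ether of compound 2 is needed for the read-out to come off the limit.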